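The source may report more compounds than this note shows. Statements on the series, on what has been measured and on what is new or still open speak of the compounds shown alone.

Of the compounds shown here, two have numbers so far. Compound 1 `Cc1c(O)c(=O)ccn1CC(=O)N/N=C1\C(=O)N(CC(=O)Nc2ccc(Cl)cc2)c2ccccc21` gives 31400 nM in a functional assay on MCF7 cells (Homo sapiens) for cytotoxicity, read by MTT assay, with a stated time of 48 h; a higher number here means that more compound is needed for the effect, a lower number that less compound is needed. Compound 2 `Cc1ccc(NC(=O)CN2C(=O)/C(=N\NC(=O)Cn3ccc(=O)c(O)c3C)c3ccccc32)cc1` gives 52200 nM in this assay. Among the measured compounds shown here, the one step between them, a 1.7-fold higher number from compound 1 to compound 2 (0.22 log units; within the scatter), lies within the scatter, so compound 2 stands at the higher of the two numbers only nominally; its nearest neighbour is compound 1 at a gap that is not a real difference.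

Compound 3 `Cc1c(O)c(=O)ccn1CC(=O)N/N=C1\C(=O)N(CC(=O)Nc2ccccc2)c2ccccc21` is not yet measured. It differs from compound 2 by hydrogen in place of methyl on an aromatic carbon. For the measured compounds named here, the only measured step that bears on substitution at this aromatic carbon is a 1.7-fold higher number from compound 1 to compound 2 (0.22 log units; within the scatter), which did not leave the scatter. Going by the values given here, no measured step informs a change to hydrogen at this position. On that basis no step beyond the scatter is expected from compound 2 to compound 3 in this assay, with a 1.1-fold lower number from compound 2 to compound 3 (0.04 log units; within the scatter) as the expected step. Compound 3 is therefore estimated at 48000 nM, in the range 22000 nM to 105000 nM.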

Compound 3, half-maximal effective concentration: 48400 nM
Compound 3: middle estimate off by 1.0-fold (0.00 log units), on the low side; measured number inside the range.
By their numbers in this assay, from the lowest: compounds 1, 3 and 2 (each within the scatter of the next).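

The series now covers removal of the substituent as well as its exchange. In this assay the change from methyl to hydrogen gives a 1.1-fold lower number from compound 2 to compound 3 (0.03 log units; within the scatter) and the change from chloro to hydrogen gives a 1.5-fold higher number from compound 1 to compound 3 (0.19 log units; within the scatter) in the same assay. Chloro, methyl and hydrogen on this aromatic carbon, para to a large group, therefore cannot be told apart here, and no measurement at hand offers an explanation for this.

Going by these compounds, whether an amine, a carboxylic acid or a methoxy group at this position would give a step beyond the scatter remains open. Compounds 1, 2 and 3 also share the rest of their structure, so they leave open how the number responds to a change anywhere else on the molecule.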